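The compounds below may be only part of what the source reports. "The series", "measured", "known", "first", "only" and "open" are said of these compounds alone.

Compound 1 `O=C1NCCC12CCN(c1c(Cl)cncc1-c1ccoc1)CC2`: 750 nM
Compound 2 `O=C1NCCC12CCN(c1c(Cl)cncc1-c1ccsc1)CC2`: 190 nM
Compound 3 `Cc1ccc(-c2cncc(Cl)c2N2CCC3(CCNC3=O)CC2)o1`: 4950 nM

In a functional assay on MV4-11 cells (Homo sapiens) for inhibition, read by resazurin assay, with a stated time of 72 h (on this read-out lower numbers stand for stronger inhibition of growth and higher numbers for weaker inhibition of growth), compound 3 gives 4950 nM, the highest of the three numbers. Its nearest neighbour gives a 6.6-fold higher number from compound 1 to compound 3 (0.82 log units; beyond the scatter), and the furthest gives a 26-fold higher number from compound 2 to compound 3 (1.42 log units; beyond the scatter).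

Compound 4 `O=Cc1ccc(-c2cncc(Cl)c2N2CCC3(CCNC3=O)CC2)o1` alters one group of compound 3: formyl in place of methyl on an aromatic carbon, next to the ring oxygen (formyl in place of methyl on an aromatic carbon). Among the measured compounds shown here, no measured step makes this exact change. All three measured steps exchange the whole five-membered aromatic group, so they bear on it only indirectly. They still show that this part of the molecule can move the number, as in a 3.9-fold lower number from compound 1 to compound 2 (0.60 log units; beyond the scatter). Changing one substituent on the same ring should count for less than those exchanges, so a step of modest size at most is expected. Compound 3 sits at the top of the measured range with 4950 nM, so a slightly lower number is the likelier direction, though the data cannot settle this. The expected step is a 1.7-fold lower number from compound 3 to compound 4 (0.22 log units; within the scatter). The estimated value for compound 4 is 3000 nM, with an expected range of 800 nM to 10000 nM.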

Compound 4, concentration for 50% growth inhibition: 5190 nM
For compound 4 the middle estimate is 1.7-fold (0.24 log units) below the measured one; the range from low to high includes it.
By their numbers in this assay, from the lowest: compound 2; then compound 1; then compounds 3 and 4 (each within the scatter of the next).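

Among the compounds shown here, on the furan ring, at the aromatic carbon next to the ring oxygen, formyl in place of methyl is the first step that stays within the scatter in this assay (a 1.0-fold higher number from compound 3 to compound 4 (0.02 log units; within the scatter)), even though formyl adds a heavy atom and a hydrogen-bond acceptor. The gaps to the compounds with other five-membered aromatic groups stay as wide as they were for the methyl compound (a 27-fold higher number from compound 2 to compound 4 (1.44 log units; beyond the scatter); a 6.9-fold higher number from compound 1 to compound 4 (0.84 log units; beyond the scatter)), so for these four compounds the exchange of the whole group moves the number, while this substituent swap does not. Nothing measured here explains that result.

Still open, as far as these compounds go, is whether a carboxylic acid, an amine or a longer alkyl chain on this carbon would also leave the number unchanged. From the compounds shown here alone, it is equally open whether a formyl group would behave the same way on a thiophene ring.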